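One Flipped Stereocentre in Compound 2

This account rests on a few compounds, and the source may have more. Where it says the series, first, only, none or still open, it means among the compounds named here.

Values from a functional assay on MDA-MB-231 cells (Homo sapiens) for inhibition, read by MTT assay, with a stated time of 72 h (a lower number here means a stronger inhibitor, a higher number a weaker inhibitor), follow.

- Compound 1 `O=C1C[C@H]2O[C@H](C(O)O)[C@H](O)[C@H]2O1` gives 58700 nM
- Compound 2 `CO[C@@H](c1ccccc1)[C@H]1O[C@@H]2CC(=O)O[C@@H]2[C@H]1O` gives 130 nM

Compound 2 holds the lower of these two numbers, which makes it the stronger inhibitor by a margin well beyond the usual scatter of repeated measurements. Compound 3 `CO[C@H](c1ccccc1)[C@H]1O[C@@H]2CC(=O)O[C@@H]2[C@H]1O` has not yet been measured in this assay. Its structure departs from compound 2 in one way only: the two compounds have the same atoms and bonds and differ only in configuration as drawn: 1 of 5 stereo elements differ; a stereocentre at a saturated chain carbon is drawn S in compound 2 and R in compound 3. Put simply, both compounds are built from identical parts, but at a saturated chain carbon the arrangement in space is reversed, drawn S in compound 2 and R in compound 3.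

Going by the values given here, no measured pair here shows what such a reversal does, so any prediction is uncertain. Among the compounds with values here, compound 2 at 130 nM sits at the low end of the two known numbers, so a moderate move towards a weaker number is expected, although a step within the scatter remains possible. The estimated change is a 2.7-fold higher number from compound 2 to compound 3 (0.43 log units; beyond the scatter). The expected value for compound 3 is 350 nM (60 nM to 2500 nM).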

Compound 3, half-maximal inhibitory concentration: 64 nM
Compound 3: the middle estimate sits 5.5-fold (0.74 log units) above what was measured, and the stated range covers the measured number.
By their numbers in this assay, from the lowest: compound 3; then compound 2; then compound 1.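

In this assay, reversing the saturated chain carbon from S as drawn to R as drawn gives a 2.0-fold lower number from compound 2 to compound 3 (0.31 log units; beyond the scatter), so the arrangement in space at this position does affect the read-out, with the R form as the stronger inhibitor of the pair. The change is modest, but it lies beyond the usual scatter, and it can be traced to this reversal alone because of one simple fact: the fact that compounds 2 and 3 differ only in the configuration as drawn. Going by these compounds alone, compound 1 and compound 2 differ in more than one place, so only this new pair isolates a single stereocentre and shows that the position responds to configuration while atoms and bonds stay the same.

As far as these compounds go, the pair speaks only to this one carbon, so the effect of reversing any of the other four stereo elements remains open. From the compounds shown here alone, it is also open whether the preference for R would persist if the methoxy group on this carbon gave way to an amine, or if the phenyl ring gave way to a longer chain.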